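The source may hold more compounds than are shown below. What is called first, only, known or untested is meant among the compounds shown, and "the series" means these compounds.

Measured so far in a physicochemical assay for lipophilicity, at pH 7.4; a higher number here means a more lipophilic compound, a lower number a more polar compound:
compound 1 `Cc1cc(C(N)=O)nn1Cc1cc(Cl)ccc1OCc1ccccc1`: 3.7
compound 2 `Cc1cc(C(=O)Nc2ccc(F)cc2)nn1Cc1cc(Cl)ccc1OCc1ccccc1`: 3

Among these two numbers compound 1 stands highest; the only measured step, a number 0.70 log units lower from compound 1 to compound 2 (beyond the scatter), runs downward from it. Compound 3 `Cc1cc(C(=O)Nc2c(F)cccc2F)nn1Cc1cc(Cl)ccc1OCc1ccccc1` has not been measured. It differs from compound 1 in one place: 2,6-difluorophenyl in place of hydrogen on an amide-type nitrogen. This closely resembles the change behind a number 0.70 log units lower from compound 1 to compound 2 (beyond the scatter), where a fluorophenyl group also entered on the same amide-type nitrogen, so a drop of similar size is expected. For compound 3 the expected step is a number 0.60 log units lower from compound 1 to compound 3 (beyond the scatter). Compound 3 is therefore estimated at 3.1, likely between 2.6 and 3.6.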

Compound 3, distribution coefficient: 3.7
Estimate against measurement, compound 3: 0.60 log units below; measured number outside the range, above it.
By their numbers in this assay, from the lowest: compound 2; then compounds 1 and 3 (each within the scatter of the next).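

In this assay, placing 2,6-difluorophenyl on the amide-type nitrogen gives no change at the digits printed from compound 1 to compound 3 (within the scatter) and so shows that adding a fluorinated ring here need not lower the number. Exchanging the ring of compound 2 gives a number 0.70 log units higher from compound 2 to compound 3 (beyond the scatter) and so shows that the number depends on which fluorophenyl group sits at this position. Nothing available explains this difference.

Still open, on these data alone, is whether an unsubstituted phenyl ring on this nitrogen would fall nearer compound 2 or compound 3. As far as these compounds go, a non-aromatic group, such as a methyl or a longer alkyl chain, is equally open.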